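The source may hold more compounds than are shown below. What is called first, only, known or untested is meant among the compounds shown, and "the series" means these compounds.

Series notes. Three measured compounds share one core and differ only in the aryl group on a saturated chain carbon bound to an amine nitrogen. Compound 1 `O=S(=O)(NCCCNCc1ccc(Cl)cc1)c1cc(C(F)(F)F)cc(C(F)(F)F)c1` gives in a functional assay on BE(2)-C cells (Homo sapiens) for inhibition, read by MTT assay, with a stated time of 72 h (on this read-out lower numbers stand for stronger inhibition of growth and higher numbers for weaker inhibition of growth), a value of 2900 nM; compound 2 `COc1cccc(CNCCCNS(=O)(=O)c2cc(C(F)(F)F)cc(C(F)(F)F)c2)c1` gives 4500 nM; compound 3 `COc1ccccc1CNCCCNS(=O)(=O)c1cc(C(F)(F)F)cc(C(F)(F)F)c1` gives 3600 nM. Compound 3 holds the second highest of the three numbers, with compound 1 nearest and compound 2 furthest, and all three values lie within the scatter of one another. For the measured compounds named here, the steps so far read a 1.6-fold higher number from compound 1 to compound 2 (0.19 log units; within the scatter), a 1.2-fold higher number from compound 1 to compound 3 (0.09 log units; within the scatter) and a 1.3-fold lower number from compound 2 to compound 3 (0.10 log units; within the scatter), so none of the aryl exchanges examined has moved the read-out beyond the scatter.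

Compound 4 `O=S(=O)(NCCCNCc1ccc(Cl)c(Cl)c1)c1cc(C(F)(F)F)cc(C(F)(F)F)c1` is not yet measured. The change from compound 3 is 3,4-dichlorophenyl in place of 2-methoxyphenyl on a saturated chain carbon bound to an amine nitrogen, that is, (2-methoxybenzyl)amino to (3,4-dichlorobenzyl)amino. All three measured steps bear on it: each exchanges the aryl group at the same place, and each stayed within the scatter. Compound 4 is therefore expected to sit with the others, the step of a 1.3-fold lower number from compound 3 to compound 4 (0.11 log units; within the scatter) being an estimate of no change beyond the scatter. The expected value for compound 4 in this assay is 2800 nM, with a range from 1200 nM to 6500 nM.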

Compound 4, concentration for 50% growth inhibition: 2900 nM
The estimate for compound 4 lay 1.0-fold (0.02 log units) below the measured number, within the range that was stated.
By their numbers in this assay, from the lowest: compounds 1, 4, 3 and 2 (each within the scatter of the next).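

In this assay, for the compounds shown here, chloro in place of hydrogen on an aromatic carbon gives no change at the digits printed from compound 1 to compound 4 (within the scatter), so a second chlorine on the aryl group leaves the read-out where the single chlorine of compound 1 had it. The comparison with the methoxy compounds gives a 1.2-fold lower number from compound 3 to compound 4 (0.09 log units; within the scatter) for 3,4-dichlorophenyl in place of 2-methoxyphenyl and a 1.6-fold lower number from compound 2 to compound 4 (0.19 log units; within the scatter) for the same group in place of 3-methoxyphenyl, so the position on a saturated chain carbon bound to an amine nitrogen now accepts a dichlorinated ring, which counts no hydrogen-bond acceptor, as well as methoxy-bearing rings without a step beyond the scatter. No measurement at hand accounts for this flat read-out.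

The compounds shown carry only chloro and methoxy on the aryl group, so it remains open whether a carboxylic acid, a dimethylamino group or a nitrile there would also stay within the scatter. Also open, on these data alone, is whether the same flatness would hold with a longer chain between the two nitrogens or with other groups in place of the trifluoromethyl groups on the shared core.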